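The compounds below may be only part of what the source reports. "The series", "measured", "known", "first", "only" and "open" are said of these compounds alone.

Measured so far:
- compound 1 `COc1ccc(Sc2c(C)n(CC(=O)O)c3ccc(C)cc23)cc1`, in an assay on isolated protein for displacement of a labelled ligand from prostaglandin D2 receptor 2 (Homo sapiens) (a higher number here means a weaker inhibitor, a lower number a stronger inhibitor), compound 1 gives 7.1 nM
- compound 2 `Cc1c(S(=O)(=O)c2ccc(Cl)cc2)c2cc(F)ccc2n1CC(=O)O`, compound 2 gives 7.1 nM
- compound 3 `Cc1c(Sc2ccc(Cl)cc2)c2c(-c3nccs3)cccc2n1CC(=O)O`, compound 3 gives 3.5 nM

Compound 3 has the lowest number of the three, and its gaps to compound 1 and to compound 2 both lie beyond the usual scatter, so it is the strongest inhibitor shown. The unmeasured compound 4 `CNC(=O)c1cccc2c1c(Sc1ccc(Cl)cc1)c(C)n2CC(=O)O` differs from compound 3 in one place: methylcarbamoyl in place of 1,3-thiazol-2-yl on an aromatic carbon. For the measured compounds named here, no measured pair shows this change, so its effect is unknown; a modest step upward, slightly beyond the scatter, seems most likely. Compound 4 is therefore expected at about 8 nM, within 2.5 nM to 30 nM, which means an expected step of a 2.3-fold higher number from compound 3 to compound 4 (0.36 log units; beyond the scatter).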

Compound 4, half-maximal inhibitory concentration: 45 nM
The estimate for compound 4 lay 5.6-fold (0.75 log units) below the measured number; measured number above the stated range.
By their numbers in this assay, from the lowest: compound 3; then compounds 1 and 2 (each within the scatter of the next); then compound 4.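

On this aromatic carbon the choice of group matters: in this assay, methylcarbamoyl in place of 1,3-thiazol-2-yl gives a 13-fold higher number from compound 3 to compound 4 (1.11 log units; beyond the scatter) and so a clearly weaker inhibitor. The change removes a five-membered aromatic ring and brings in an open group with a hydrogen-bond donor, and this single pair cannot separate those two differences. No measurement shown here explains the loss.

Still open, on these data alone, is whether another five-membered aromatic ring, such as oxazol-2-yl, would keep the lower number. An amine or a plain hydrogen on this carbon would show how much any group here contributes.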